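This account rests on a few compounds, and the source may have more. Where it says the series, first, only, none or still open, it means among the compounds named here.

Series on a shared core, read in a toxicity assay on NIH3T3 cells (Mus musculus) for cytotoxicity, read by resazurin assay; on this read-out higher numbers stand for an effect only at larger amounts of compound and lower numbers for an effect already at smaller amounts. Compound 1 `COC(=O)c1ccc(NCc2cncn2Cc2ccccc2Cl)cc1-c1ccccc1` gives 10000 nM. For compound 2 `COC(=O)c1ccc(NCc2cncn2Cc2ccc(N)cc2)cc1-c1ccccc1` the reading is a limit of the assay, > 10000 nM. Compound 3 `COC(=O)c1ccc(NCc2cncn2Cc2cccc(C#N)c2)cc1-c1ccccc1` likewise sits at a limit of the assay, > 10000 nM. Two of the three values shown are such limits (the limit of > 10000 nM in this assay, at which 2 of the 3 values shown sit), so compound 3 stands among the compounds without a number; the measured step that reaches it is a number no lower from compound 1 to compound 3 (the limit leaves the size open), and the pair with compound 2 gives a step that the two limits leave unreadable from compound 2 to compound 3.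

Compound 4 `COC(=O)c1ccc(NCc2cncn2Cc2ccc(F)cc2F)cc1-c1ccccc1` differs from compound 3 by 2,4-difluorophenyl in place of 3-cyanophenyl on a saturated chain carbon bound to an aromatic nitrogen. Going by the values given here, the steps that bear on this change are a number no lower from compound 1 to compound 2 (the limit leaves the size open) and a number no lower from compound 1 to compound 3 (the limit leaves the size open), both leaving their size open, together with a step that the two limits leave unreadable from compound 2 to compound 3. Among the compounds with values here, no measured step shows a number lower than the reading of compound 1, so no step beyond the scatter is expected in this assay; for compound 4 the expected step is a number no higher from compound 3 to compound 4 (the limit leaves the size open). Compound 4 is therefore estimated at 10000 nM, between 5000 nM and 30000 nM, with a limit the likeliest outcome.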

Compound 4, half-maximal effective concentration: > 1000 nM
Compound 4 was reported as a limit; the forecaster's own chance of this, stated with the estimate: 70%; the middle value does not contradict the limit.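

In this assay compound 4 gives > 1000 nM, a limit of the assay. Going by these compounds alone, no step from compound 1, compound 2 or compound 3 to compound 4 can be read. The compounds shown leave open the size of any effect of changing the benzyl group on the shared core.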